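Replacing the tert-butylphenoxy group with phenyl: expected acidity

The compounds below may be only part of what the source reports. "The series", "measured", "known", "first", "only" and "open" are said of these compounds alone.

Compound 2 `COc1ccc(F)cc1CNCCCNc1ccnc2cc(Oc3ccc(C(C)(C)C)cc3)ccc12` was measured in a physicochemical assay for acid dissociation, where compound 2 gives 9.28. Going by the values given here, only one other number exists for comparison: compound 1 `COc1ccc(F)cc1CNCCCNc1ccnc2cc(Cc3ccc(F)cc3Cl)ccc12`, which in this assay gives 9.47. The change a number 0.19 log units lower from compound 1 to compound 2 (within the scatter) came from placing 4-(tert-butyl)phenoxy in place of 2-chloro-4-fluorobenzyl on an aromatic carbon, so the two numbers cannot be told apart.

Compound 3 `COc1ccc(F)cc1CNCCCNc1ccnc2cc(-c3ccccc3)ccc12` has not yet been measured. It differs from compound 2 by phenyl in place of 4-(tert-butyl)phenoxy on an aromatic carbon. Among the compounds with values here, the only step that bears on this change is the one from compound 1 to compound 2, which swapped a group at the same aromatic carbon and stayed within the scatter. A further swap there is therefore expected to leave the number essentially unchanged, and the expected step is a number 0.07 log units higher from compound 2 to compound 3 (within the scatter). For compound 3 the estimated value in this assay is 9.35, with a range from 9 to 9.7.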

Compound 3, acid dissociation constant: 9.47
Estimate against measurement, compound 3: 0.12 log units below; low and high end bracket the measured number.
By their numbers in this assay, from the lowest: compounds 2, 1 and 3 (each within the scatter of the next).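

In this assay the swap of 4-(tert-butyl)phenoxy for phenyl gives a number 0.19 log units higher from compound 2 to compound 3 (within the scatter) and the swap of 2-chloro-4-fluorobenzyl for phenyl gives no change at the digits printed from compound 1 to compound 3 (within the scatter) at the same aromatic carbon. Going by these compounds alone, this position has now carried three different groups, including phenyl, which has no hydrogen-bond acceptor, and no step among compounds 1, 2 and 3 lies beyond the scatter, so this read-out does not separate them. No measurement shown here offers a reason for this result.

As far as these compounds go, it remains open whether a group of a different kind at this aromatic carbon, such as an amine or a carboxylic acid, would give a number beyond the scatter. The compounds shown also leave open how the number would respond to a longer chain in place of the one that all three share.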